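Compound 3: Relocating the Hydroxy Group

The source may hold more compounds than are shown below. What is called first, only, known or untested is meant among the compounds shown, and "the series" means these compounds.

Within the data shown here, compound 2 `O=C(N/N=C/c1cccc(O)c1)c1cccnc1Nc1cccc(C(F)(F)F)c1` stands highest of the two compounds measured so far in a functional assay on the whole organism (strain Wistar) for inhibition, with Rattus norvegicus as the target, read by paw edema, with a stated time of 1 h, at a dose of 10 mg/kg by the intraperitoneal route (on this read-out lower numbers stand for less inhibition and higher numbers for more inhibition at the one dose given (going by the name of the read-out)), where compound 2 gives 63.8%. Among the measured compounds shown here, its nearest neighbour, compound 1 `O=C(N/N=C/c1cccc(F)c1)c1cccnc1Nc1cccc(C(F)(F)F)c1`, gives 51.5% in the same test, and the step of a number 12.3 percentage points higher from compound 1 to compound 2 (beyond the scatter) is the only measured change available.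

Compound 3 `O=C(N/N=C/c1ccc(O)cc1)c1cccnc1Nc1cccc(C(F)(F)F)c1` differs from compound 2 in one place: 4-hydroxyphenyl in place of 3-hydroxyphenyl on a carbon with a double bond to nitrogen. For the measured compounds named here, no measured step bears directly on this change, since the one step recorded, a number 12.3 percentage points higher from compound 1 to compound 2 (beyond the scatter), exchanges one substituent for another rather than moving the same substituent to a different place on the ring. Going by the values given here, the only guide is therefore the value of compound 2 itself. An expected step of a number 1.8 percentage points lower from compound 2 to compound 3 (within the scatter) of no size beyond the scatter is the most defensible estimate. Compound 3 is thus expected to give 62%, with a plausible range from 48% to 76%.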

Compound 3, a percentage reported as inhibition, in the whole organism at one dose (the size of the read-out at that dose, not a potency): 70.5%
The estimate for compound 3 lay 8.5 percentage points below the measured number; the measured number falls inside the stated range.
By their numbers in this assay, from the lowest: compound 1; then compounds 2 and 3 (each within the scatter of the next).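

In this assay, 4-hydroxyphenyl in place of 3-hydroxyphenyl on a carbon with a double bond to nitrogen gives a number 6.7 percentage points higher from compound 2 to compound 3 (within the scatter), so on this read-out, at this one dose, the two hydroxyphenyl groups cannot be told apart. At the same carbon, 4-hydroxyphenyl in place of 3-fluorophenyl gives a number 19 percentage points higher from compound 1 to compound 3 (beyond the scatter), which places compound 1 clearly apart from compound 3, as it already stood apart from compound 2. No measurement is available that would account for these numbers.

The compounds shown leave open whether a methoxy group, an amine or a carboxylic acid in place of the hydroxy group of compound 3 would hold this level of inhibition. They also leave open whether the closeness of compound 2 and compound 3 would persist at other doses or times.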